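This account rests on a few compounds, and the source may have more. Where it says the series, first, only, none or still open, it means among the compounds named here.

Compound 1 `Cn1ncc2c(NC(=O)NCc3cc(C(F)(F)F)nn3-c3ccc(Cl)cc3)cccc21` gives 2.7 nM in an assay on CHO-K1 cells for antagonist activity at transient receptor potential cation channel subfamily V member 1 (Homo sapiens), read by FLIPR and calcium flux, with a stated time of 6 min (a higher number here means a weaker inhibitor, a lower number a stronger inhibitor), the lower of the two numbers at hand, though compound 2 `Cc1ccc(-n2nc(C(F)(F)F)cc2CNC(=O)Nc2cccc3c2cnn3C)cc1C`, which gives 3.5 nM in this assay, sits close: the step of a 1.3-fold higher number from compound 1 to compound 2 (0.11 log units; within the scatter) comes from a 3,4-dimethylphenyl in place of 4-chlorophenyl on an aromatic nitrogen. Compound 3 `Cn1ncc2c(NC(=O)NCc3cc(C(C)(C)C)nn3-c3ccc(Cl)cc3)cccc21` differs from compound 1 by tert-butyl in place of trifluoromethyl on an aromatic carbon. Going by the values given here, no measured step touches this place, so nothing recorded bears on it, and the expected change is none beyond the scatter: a 1.9-fold higher number from compound 1 to compound 3 (0.27 log units; within the scatter). Compound 3 is therefore estimated at 5 nM, between 1 nM and 25 nM.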

Compound 3, inhibition constant: 9.5 nM
Compound 3: middle estimate off by 1.9-fold (0.28 log units), on the low side, and the stated range covers the measured number.
By their numbers in this assay, from the lowest: compounds 1 and 2 (each within the scatter of the next); then compound 3.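

Unlike the earlier step on the aromatic nitrogen, this change on an aromatic carbon of the five-membered ring moves the number beyond the scatter, with tert-butyl in place of trifluoromethyl: a 3.5-fold higher number from compound 1 to compound 3 (0.55 log units; beyond the scatter). The two groups match in heavy atoms, rings, hydrogen-bond donors and hydrogen-bond acceptors, so those counts do not separate them. Nothing at hand says why the number moves. Going by these compounds, whether methyl, an amine or a nitrile would hold the number at this carbon stays open, as does whether tert-butyl would bring the same step alongside the 3,4-dimethylphenyl group of compound 2.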